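Carboxy in place of pyridin-4-yl: compound 3 to compound 4

This account rests on a few compounds, and the source may have more. Where it says the series, first, only, none or still open, it means among the compounds named here.

Of the compounds shown here, three sharing one core have been measured in an ADME assay on S9 fraction from liver (Rattus norvegicus) for metabolic stability, read by LC-MS, using NADPH, with a stated time of 30 min; a higher number here means that more of the compound is left, a lower number that less of the compound is left. Compound 1 `CCCCCCCCc1ccc(OCC(=O)Cn2nnc(-c3ccc(S(=O)(=O)N(C)C)cc3)n2)cc1` gives 65%. Compound 2 `CCCCCCCCc1ccc(OCC(=O)Cn2nnc(-c3cccc(S(=O)(=O)N(C)C)c3)n2)cc1` gives 9%, and the large step of a number 56 percentage points lower from compound 1 to compound 2 (beyond the scatter) comes from moving the dimethylsulfamoyl group alone. Compound 3 `CCCCCCCCc1ccc(OCC(=O)Cn2nnc(-c3ccncc3)n2)cc1` reads < 5%, which is a limit of the assay and not a number. Compound 3 therefore stands on (the limit of < 5% in this assay, at which 1 of the 3 values shown sits). The large step of a number at least 60 percentage points lower from compound 1 to compound 3 (beyond the scatter) sets it apart from compound 1, whereas a number at least 4 percentage points lower from compound 2 to compound 3 (that floor lies within the scatter) does not separate it from compound 2.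

Compound 4 `CCCCCCCCc1ccc(OCC(=O)Cn2nnc(C(=O)O)n2)cc1` is the next case, with carboxy in place of pyridin-4-yl on an aromatic carbon. All three measured steps concern the group at this same place, and two of them are large, so a substantial shift cannot be ruled out. None of them involves carboxy, however, so their sizes carry over only loosely. The expectation of a modest rise rests on compound 1, whose 65% shows that a change at this place can lift the value a long way. The expected step is a number at least 15 percentage points higher from compound 3 to compound 4 (beyond the scatter). Compound 4 is estimated at 20%, with an expected range of 5% to 55%.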

Compound 4, percent of the compound remaining: 52%
Compound 4: the middle estimate sits 32 percentage points below what was measured, within the range that was stated.
By their numbers in this assay, from the lowest: compound 2; then compound 4; then compound 1. At a limit, below all of these: compound 3.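

In this assay, this position does not need a ring to give a high reading: carboxy, which has no ring, gives a number at least 47 percentage points higher from compound 3 to compound 4 (beyond the scatter) and also a number 43 percentage points higher from compound 2 to compound 4 (beyond the scatter). Among the compounds shown here, the 4-(dimethylsulfamoyl)phenyl group still stays ahead of carboxy, with a number 13 percentage points lower from compound 1 to compound 4 (beyond the scatter), so compound 1 is no longer the only compound well clear of the low readings, and the group that replaces it here shares no ring with it. The first of these steps gives a floor and not a full size, as compound 3 stands at a limit of the assay: the limit of < 5% in this assay, at which 1 of the 4 values shown sits.

As far as these compounds go, whether the reading of compound 4 belongs to carboxy itself remains open, as a methyl ester, a primary amide or an amine at the same place could show whether other small groups with no ring read alike. The compounds shown also do not tell which part of the molecule is lost during the incubation, so it remains unclear whether the group at this position acts on that loss directly or only through the rest of the shared core.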